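Methoxy in place of methyl on an aromatic carbon

The source may report more compounds than this note shows. Statements on the series, on what has been measured and on what is new or still open speak of the compounds shown alone.

- compound 1 `NC(=O)c1c(NC(=O)c2ccc(Cl)cc2)sc2c1CCCC2` gives 1400 nM
- compound 2 `Cc1cccc(C(=O)Nc2sc3c(c2C(N)=O)CCCC3)c1` gives 3200 nM

Both compounds were tested in a functional assay on MV4-11 cells (Homo sapiens) for antiproliferative activity (on this read-out lower numbers stand for stronger inhibition and higher numbers for weaker inhibition), and compound 2, at 3200 nM in that test, holds the higher of the two numbers, which makes it the weaker inhibitor so far. Compound 3 `COc1cccc(C(=O)Nc2sc3c(c2C(N)=O)CCCC3)c1` carries methoxy in place of methyl on an aromatic carbon meta to a large group. Within the data shown here, only one measured step bears on this: a 2.3-fold higher number from compound 1 to compound 2 (0.36 log units; beyond the scatter) and it was modest. Among the measured compounds shown here, that step replaced the whole group on the carbonyl carbon, and no measured compound carries methoxy. Since the step of a 2.3-fold higher number from compound 1 to compound 2 (0.36 log units; beyond the scatter) stayed modest, no change beyond the usual scatter is expected in this assay and no direction is favoured. The expected result is a 1.1-fold lower number from compound 2 to compound 3 (0.03 log units; within the scatter) as an estimate only. For compound 3 the estimated value is 3000 nM (expected range 1200 nM to 7500 nM).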

Compound 3, half-maximal inhibitory concentration: 1500 nM
Estimate against measurement, compound 3: 2.0-fold (0.30 log units) above; low and high end bracket the measured number.
By their numbers in this assay, from the lowest: compounds 1 and 3 (each within the scatter of the next); then compound 2.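

In this assay, the swap of methyl for methoxy, meta to a large group, gives a 2.1-fold lower number from compound 2 to compound 3 (0.33 log units; beyond the scatter) and counts as a modest step. This shows that a small edit at this one place on the ring can move the number beyond the scatter, which the earlier step could not show, as it replaced the whole group on the carbonyl carbon. Compound 3 and compound 1 now lie within the scatter of each other, and nothing measured here explains why methoxy gives the lower number.

From the compounds shown here alone, whether an ethoxy group or a hydroxyl group at the same place would lower the number further remains open. So does whether methoxy would give a similar step elsewhere on this ring.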